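A few compounds are considered here, and "the series" means these few. Any claim that something is new, unique, unknown or untested is made for them only; others in the source may bear on it.

Three compounds have been measured in an ADME assay on microsomes from liver (Homo sapiens) for metabolic stability, read by LC-MS, using NADPH, with stated times of 5 min and 30 min, tested at 1 uM; on this read-out lower numbers stand for slow clearance and higher numbers for fast clearance:

Compound 1 `CN(c1ccn(C)n1)c1cnc(NCc2c(F)ccc3c2CCO3)c2cn[nH]c(=O)c12`: 62 mL.min-1.g-1
Compound 2 `O=C1CCCN1c1cnc(NCc2c(F)ccc3c2CCO3)c2cn[nH]c(=O)c12`: 23 mL.min-1.g-1
Compound 3 `CC(=O)N1CCC(c2cnc(NCc3c(F)ccc4c3CCO4)c3cn[nH]c(=O)c23)CC1`: 207 mL.min-1.g-1

All three share one core and differ only in the group attached at a single aromatic carbon. Among the measured compounds shown here, on the numbers so far, compound 3 stands highest, which here means the fastest clearance: the steps to it are a 3.3-fold higher number from compound 1 to compound 3 (0.52 log units; beyond the scatter) and a 9.0-fold higher number from compound 2 to compound 3 (0.95 log units; beyond the scatter), both beyond the scatter of this assay. The third measured step, a 2.7-fold lower number from compound 1 to compound 2 (0.43 log units; beyond the scatter), shows that a change at this same position can also move the number in the other direction.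

Compound 4 `Cc1ncccc1-c1cnc(NCc2c(F)ccc3c2CCO3)c2cn[nH]c(=O)c12` is the next compound, not yet measured. Its change from compound 3 is 2-methylpyridin-3-yl in place of 1-acetylpiperidin-4-yl on an aromatic carbon. Every measured step touches this same position, so all three bear on the question, but none of them brings in an aromatic ring in place of a saturated one, so none matches the change closely. For the measured compounds named here, since compound 3 gave the highest number so far and each group tried at this position gave a lower one, the expected step is a 3.0-fold lower number from compound 3 to compound 4 (0.47 log units; beyond the scatter), a modest move toward slower clearance, with wide uncertainty. Compound 4 is therefore estimated at 70 mL.min-1.g-1, within a range from 25 mL.min-1.g-1 to 200 mL.min-1.g-1.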

Compound 4, intrinsic clearance in microsomes: 41 mL.min-1.g-1
Compound 4: the middle estimate sits 1.7-fold (0.23 log units) above what was measured, within the range that was stated.
By their numbers in this assay, from the lowest: compounds 2, 4 and 1 (each within the scatter of the next, the first and the last beyond it); then compound 3.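

In this assay a saturated ring and an aromatic ring of the same six-membered size, both joined through carbon at this aromatic carbon, do not give the same result: putting the 2-methylpyridin-3-yl group in place of the 1-acetylpiperidin-4-yl group gives a 5.0-fold lower number from compound 3 to compound 4 (0.70 log units; beyond the scatter) and leaves compound 3 alone at the top of the series. The new group also lands among the earlier ones, with a 1.8-fold higher number from compound 2 to compound 4 (0.25 log units; within the scatter) and a 1.5-fold lower number from compound 1 to compound 4 (0.18 log units; within the scatter) both printed as within the scatter, so compound 4 cannot be ranked against either neighbour, even though compound 1 and compound 2 stand apart from each other and their groups look quite different. No measurement here explains why the piperidine-bearing compound 3 stands apart from the other three.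

As far as these compounds go, whether the high number of compound 3 goes with its acetyl group or with its saturated ring stays open, as does the part played by the methyl on the pyridine ring. A piperidin-4-yl carrying a free amine and a plain pyridin-3-yl would speak to these two questions.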